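Chloro-for-hydrogen on the core of compound 2

The source may hold more compounds than are shown below. What is called first, only, known or untested is meant among the compounds shown, and "the series" means these compounds.

Measured compounds:
Compound 1 `Nc1nc(Cl)c2ncn(Cc3ccccc3CCl)c2n1`, > 100000 nM
Compound 2 `ClCc1ccc(Cn2cnc3ncnc(Cl)c32)cc1`, 2690 nM

Of the compounds shown here, two have been tested in a functional assay on RPMI-8226 cells (Homo sapiens) for cytotoxicity, read by sulforhodamine B assay, with a stated time of 48 h; on this read-out higher numbers stand for weaker inhibition of growth and lower numbers for stronger inhibition of growth. Compound 1 `Nc1nc(Cl)c2ncn(Cc3ccccc3CCl)c2n1` reaches only (the limit of > 100000 nM in this assay, at which 1 of the 2 values shown sits), so for compound 1 there is a limit of the assay and no number. Compound 2 `ClCc1ccc(Cn2cnc3ncnc(Cl)c32)cc1` gives 2690 nM in this assay, and this is the only number shown. Compound 1 sits at a limit of the assay, and so compound 2 cannot be ranked against anything measured. Compound 3 `ClCc1ccc(Cn2cnc3nc(Cl)nc(Cl)c32)cc1` has not yet been measured in this assay. It differs from compound 2 in one place: chloro in place of hydrogen on an aromatic carbon.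

No step between measured compounds is shown, so there is nothing to calibrate what this change does. The account therefore expects a step of about a 1.8-fold lower number from compound 2 to compound 3 (0.25 log units; within the scatter), a small shift toward stronger inhibition of growth that may lie within the scatter. Compound 3 is estimated at 1500 nM, with a range from 400 nM to 6000 nM.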

Compound 3, concentration for total growth inhibition: 28200 nM
For compound 3 the middle estimate is 19-fold (1.27 log units) below the measured one; measured number above the stated range.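

In this assay, chloro in place of hydrogen on the aromatic carbon between two ring nitrogen atoms gives a 10-fold higher number from compound 2 to compound 3 (1.02 log units; beyond the scatter) and moves the series toward weaker inhibition of growth. Among the compounds shown here, this is the first step that can be read between two measured compounds, and it shows that this position on the six-membered aromatic ring is not indifferent to change: one added chlorine atom takes away much of the inhibition of growth that compound 2 shows. Nothing among the data shown bears on why this change has such an effect.

The compounds shown leave open whether the loss is particular to chloro or would also follow with a methyl group, a methoxy group or a carboxylic acid on the same carbon. For the compounds shown here, they also leave open whether the step would keep its size with another group at the other chloro position or with another benzyl substituent, since this single pair is the only comparison that can be read.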